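A few compounds are considered here, and "the series" means these few. Any claim that something is new, unique, unknown or untested is made for them only; others in the source may bear on it.

Measured compounds in a functional assay on SK-OV-3 cells (Homo sapiens) for inhibition, read by sulforhodamine B assay, with a stated time of 48 h, tested at 1 uM; a lower number here means a stronger effect, a higher number a weaker effect of the compound at the concentration tested:

- compound 1 `COc1cc(Cl)cc(-c2nn(-c3cccc(NC(=O)Nc4ccc(Cl)c(C(F)(F)F)c4)c3)cc2-c2ccncc2)c1` gives 100%
- compound 2 `COc1cc(Cl)cc(-c2nn(-c3cccc(NC(=O)Nc4cc(C(F)(F)F)cc(C(F)(F)F)c4)c3)cc2-c2ccncc2)c1` gives 43%
- compound 3 `COc1cc(Cl)cc(-c2nn(-c3cccc(NC(=O)Nc4ccc(Cl)c(Cl)c4)c3)cc2-c2ccncc2)c1` gives 100%

Compound 3 stands level with compound 1 at the digits shown, the two together the highest of the three numbers; compound 2 lies well below both, beyond the scatter. Within the data shown here, the one single-point step available, no change at the digits printed from compound 1 to compound 3 (within the scatter), shows that exchanging chloro for trifluoromethyl on the aromatic carbon of the urea aryl group leaves the read-out unchanged within the scatter.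

Compound 4 `COc1cc(Cl)cc(-c2nn(-c3cccc(NC(=O)Nc4cccc(C(F)(F)F)c4)c3)cc2-c2ccncc2)c1` differs from compound 3 by 3-(trifluoromethyl)phenyl in place of 3,4-dichlorophenyl on an amide-type nitrogen. Among the measured compounds shown here, no measured pair isolates the loss of one aryl substituent on that ring, so the step from compound 1 to compound 3 bears only loosely: it suggests the identity of a single substituent there matters little. Compound 2, carrying two trifluoromethyl groups, shows a much lower number than compound 3, which cautions that the substitution pattern on this ring can move the read-out. Compound 4 is therefore expected to sit a little below compound 3, with a number 15 percentage points lower from compound 3 to compound 4 (beyond the scatter), giving an estimated value for compound 4 of 85% with a range from 50% to 100%.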

Compound 4, a percentage reported as activity, at one concentration (the size of the read-out at that concentration, not a potency): 103%
Estimate against measurement, compound 4: 18 percentage points below; the measured number lies above the stated range.
By their numbers in this assay, from the lowest: compound 2; then compounds 1, 3 and 4 (each within the scatter of the next).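

In this assay, 3-(trifluoromethyl)phenyl on the amide-type nitrogen in place of 3,4-dichlorophenyl gives a number 3 percentage points higher from compound 3 to compound 4 (within the scatter), so this exchange leaves the read-out unchanged within the scatter. Hydrogen in place of chloro on the aromatic carbon gives a number 3 percentage points higher from compound 1 to compound 4 (within the scatter), so the chloro of compound 1 is not needed to hold this reading. Hydrogen in place of trifluoromethyl on the aromatic carbon, by contrast, gives a number 60 percentage points higher from compound 2 to compound 4 (beyond the scatter), which ties the low number of compound 2 to its second trifluoromethyl group, the only single change in this set that moves the read-out beyond the scatter.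

No measured property bears on these steps. Open, going by these compounds, is whether a second substituent other than trifluoromethyl on that ring, such as an amine or a carboxylic acid, also lowers the number.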